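Moving the hydroxyl on a terphenyl-like pyridine series

The compounds below may be only part of what the source reports. "The series", "measured", "known", "first", "only" and "open" are said of these compounds alone.

Compound 1 `Oc1cccc(-c2cc(-c3cccc(C(F)(F)F)c3)cc(-c3cccc(O)c3)n2)c1` gives 13600 nM in a functional assay on HCT-15 cells (Homo sapiens) for inhibition; a lower number here means a stronger inhibitor, a higher number a weaker inhibitor. Compound 2 `Oc1ccc(-c2cc(-c3cccc(C(F)(F)F)c3)cc(-c3cccc(O)c3)n2)cc1` gives 9540 nM in this assay. The change between them, (4-hydroxyphenyl in place of 3-hydroxyphenyl on an aromatic carbon), gave a 1.4-fold lower number from compound 1 to compound 2 (0.15 log units; within the scatter). Compound 3 `Oc1cccc(-c2cc(-c3ccc(OC(F)(F)F)cc3)cc(-c3cccc(O)c3)n2)c1` carries a different core; how the core of compound 1 and the core of compound 3 differ is not broken down here. In this assay compound 3 gives only a limit, > 50000 nM, and no number. Compound 4 `Oc1ccc(-c2cc(-c3ccc(OC(F)(F)F)cc3)cc(-c3cccc(O)c3)n2)cc1` has not yet been measured; it differs from compound 3 by 4-hydroxyphenyl in place of 3-hydroxyphenyl on an aromatic carbon. This is the same kind of change as that from compound 1 to compound 2, though the surroundings are not the same word for word: in compound 1 the place is meta to a 3-(trifluoromethyl)phenyl group, in compound 3 it is meta to a large group. Compound 4 is expected to show a step that the limit leaves unreadable from compound 3 to compound 4, a step of about the size seen before, resting on the earlier step of a 1.4-fold lower number from compound 1 to compound 2 (0.15 log units; within the scatter) and on compound 3 giving > 50000 nM at the limit (the limit of > 50000 nM in this assay, at which 1 of the 3 values shown sits). Compound 4 is therefore estimated at 60000 nM, between 25000 nM and 150000 nM, with a real chance that only a limit is reported.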

Compound 4, half-maximal inhibitory concentration: 1380 nM
Compound 4: middle estimate off by 43-fold (1.64 log units), on the high side; the whole stated range lies above it.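

In this assay the change from 3-hydroxyphenyl to 4-hydroxyphenyl gave an at least 36-fold lower number from compound 3 to compound 4 (1.55 log units; beyond the scatter), so it did not carry over at the same size from one core to the other: the same change on two cores in this assay, a 1.4-fold lower number (0.15 log units; within the scatter) from compound 1 to compound 2 and an at least 36-fold lower number (1.55 log units; beyond the scatter) from compound 3 to compound 4, at least 25-fold (1.40 log units) apart, beyond the scatter of two such steps

Compound 3 gives > 50000 nM, which is a limit and not a number, so the step from it has a bound rather than an exact size: the limit of > 50000 nM in this assay, at which 1 of the 4 values shown sits.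

The two pairs show that, here, the small step on the core of compound 1 was no guide to the step on the core of compound 3; they do not show why the cores differ, and two pairs set no rule for the series.

The compounds shown leave open whether the larger step would recur on any further core. They also leave open whether a methoxy group, an amine or a carboxylic acid in place of the hydroxyl of the 4-hydroxyphenyl group would keep the gain seen with compound 4.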